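Removing the acetyl from the side chain of compound 3

The compounds below may be only part of what the source reports. "The series", "measured", "known", "first", "only" and "open" are said of these compounds alone.

Compound 2, `CC(=O)OCCOn1cnc2c(S)nc(N)nc21`, gives 3200 nM in a functional assay on L1210 cells (Mus musculus) for inhibition; a lower number here means a stronger inhibitor, a higher number a weaker inhibitor.
Compound 3, `CC(=O)OCCOn1cnc2c(S)nc(F)nc21`, gives 40000 nM in this assay.
Compound 1, `COc1nc(I)nc2c1ncn2OCCO`, gives only a limit in this assay, namely > 500000 nM.

Within the data shown here, of the two numbers recorded, compound 3 holds the higher one; the only measured step, a 13-fold higher number from compound 2 to compound 3 (1.10 log units; beyond the scatter), separates it from compound 2. Compound 4, `OCCOn1cnc2c(S)nc(F)nc21`, differs from compound 3 by hydrogen in place of acetyl on an oxygen on a saturated carbon. Among the measured compounds shown here, no measured step touches this part of the molecule: the one step known concerns an exchange on an aromatic carbon and says nothing about the ester end of the side chain. Compound 1 carries the same hydroxy-terminated chain as compound 4 but differs elsewhere, and it gives only a limit, so it offers no scale for this change. The change from compound 3 to compound 4 is therefore expected to stay within the scatter, no change at the digits printed from compound 3 to compound 4 (within the scatter). Compound 4 is accordingly estimated at 40000 nM, with a range from 10000 nM to 200000 nM.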

Compound 4, half-maximal inhibitory concentration: 170000 nM
The estimate for compound 4 lay 4.3-fold (0.63 log units) below the measured number; the measured number falls inside the stated range.
By their numbers in this assay, from the lowest: compound 2; then compound 3; then compound 4. At a limit, above all of these: compound 1.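

In this assay, the ester end of the side chain does affect the read-out: exchanging 2-acetoxyethyl for 2-hydroxyethyl gives a 4.3-fold higher number from compound 3 to compound 4 (0.63 log units; beyond the scatter). Among these compounds, this is the first measured step at this end of the molecule, and it shows that the acetyl on the oxygen contributes to the inhibition seen with compound 3. The earlier step, a 13-fold higher number from compound 2 to compound 3 (1.10 log units; beyond the scatter), concerned only the aromatic carbon, so the series now has a measured change at each of the two places.

From the compounds shown here alone, whether the acetyl has a similar effect with amino in place of fluoro stays open, as does whether a benzoyl ester or a methyl ether at the chain end would behave like acetoxy or like hydroxy. Compound 1 carries the 2-hydroxyethyl chain but differs elsewhere and gives only a limit: the limit of > 500000 nM in this assay, at which 1 of the 4 values shown sits.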